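A New Group on the Nitrogen of Compound 2

The compounds below may be only part of what the source reports. "The series", "measured", "known", "first", "only" and "open" are said of these compounds alone.

In a functional assay on HL-60 cells (Homo sapiens) for cytotoxicity, read by MTT assay, with a stated time of 72 h (on this read-out lower numbers stand for stronger inhibition and higher numbers for weaker inhibition), compound 1 `COc1ccc(Nc2nc3ccccc3nc2S(=O)(=O)c2ccc(C)cc2)cc1` gives 2790 nM, and compound 2 `COc1ccc(Nc2nc3ccccc3nc2S(=O)(=O)c2ccc(Br)cc2)cc1` gives 1190 nM, the lower of the two numbers. Compound 2 therefore stands as the stronger inhibitor of this pair. The next structure, compound 3 `Nc1cccc(Nc2nc3ccccc3nc2S(=O)(=O)c2ccc(Br)cc2)c1`, keeps the bromo group but changes another part of compound 2: 3-aminophenyl in place of 4-methoxyphenyl on a nitrogen on an aromatic ring. In short, 3-aminophenyl takes the place of 4-methoxyphenyl on a nitrogen on an aromatic ring. Within the data shown here, only one measured step exists, a 2.3-fold lower number from compound 1 to compound 2 (0.37 log units; beyond the scatter). It is modest, and it comes from bromo replacing methyl on an aromatic carbon, a different change at a different place. It offers a rough sense of size but no direction for the new change. A small step of uncertain direction is expected in this assay, and the estimated step is a 1.2-fold lower number from compound 2 to compound 3 (0.08 log units; within the scatter). The estimate for compound 3 is 1000 nM, with an expected range from 280 nM to 3600 nM.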

Compound 3, half-maximal inhibitory concentration: 1370 nM
Compound 3: middle estimate off by 1.4-fold (0.14 log units), on the low side; low and high end bracket the measured number.
By their numbers in this assay, from the lowest: compounds 2 and 3 (each within the scatter of the next); then compound 1.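

In this assay the swap of 4-methoxyphenyl for 3-aminophenyl on the nitrogen gives a 1.2-fold higher number from compound 2 to compound 3 (0.06 log units; within the scatter) and so produces no readable change. Compound 2 and compound 3 cannot be told apart here, even though the entering group carries a hydrogen-bond donor that the leaving group lacks. Among these compounds, this first look at the position shows that, for this one pair, an exchange of one substituted phenyl group for another leaves the cytotoxicity number unmoved, whereas the only earlier step concerned a different place. No evidence is available to explain this result. Still open, on these data alone, is whether the same holds for a group of another kind on that nitrogen, such as a carboxylic acid or a longer chain. Also open, as far as these compounds go, is whether 3-aminophenyl behaves alike with methyl in place of bromo.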